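Thiazolidinone Vero cell cytotoxicity: hydroxyphenyl for chlorophenyl

The source may hold more compounds than are shown below. What is called first, only, known or untested is meant among the compounds shown, and "the series" means these compounds.

Compound 1 `O=C1CSC(c2ccccc2Cl)N1CCN1CCCCC1` — 94%
Compound 2 `O=C1CSC(c2ccccc2[N+](=O)[O-])N1CCN1CCCCC1` — 100%

In an ADME assay on Vero cells (Chlorocebus sabaeus) for cytotoxicity, read by neutral red uptake, tested at 98 ug/mL (a lower number here means a stronger effect, a higher number a weaker effect of the compound at the concentration tested), compound 1 gives 94%, and compound 2 gives 100%. Compound 1 stands at one end of the two numbers shown, the only measured step being a number 6 percentage points higher from compound 1 to compound 2 (within the scatter). Compound 3 `O=C1CSC(c2cccc(O)c2)N1CCN1CCCCC1` carries the change (3-hydroxyphenyl in place of 2-chlorophenyl on a saturated ring carbon). Among the compounds with values here, no measured step touches this change; the one known step, nitro in place of chloro, was within the scatter. Compound 3 is therefore expected to show no step beyond the scatter, a number 2 percentage points higher from compound 1 to compound 3 (within the scatter). The estimate for compound 3 is 96%, between 85% and 100%.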

Compound 3, a percentage reported as activity, at one concentration (the size of the read-out at that concentration, not a potency): 100%
The estimate for compound 3 lay 4 percentage points below the measured number, and the stated range covers the measured number.
By their numbers in this assay, from the lowest: compounds 1, 2 and 3 (each within the scatter of the next).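

In this assay, putting 3-hydroxyphenyl in place of 2-chlorophenyl on the saturated ring carbon gives a number 6 percentage points higher from compound 1 to compound 3 (within the scatter) and so stays inside the usual spread. The earlier step only exchanged one group for another on the same aromatic carbon, whereas this one replaces the whole aryl group with one carrying a hydrogen-bond donor and acceptor, and no step beyond the scatter appears. Nothing available accounts for this result. From the compounds shown here alone, whether an amine, a carboxylic acid or a longer chain on this ring carbon would give a step beyond the scatter remains open.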